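Trimethoxyphenyl pyrazolopyrimidines: swapping indolyl for vinylphenyl

A few compounds are considered here, and "the series" means these few. Any claim that something is new, unique, unknown or untested is made for them only; others in the source may bear on it.

Three compounds have numbers in a functional assay on HCT-116 cells (Homo sapiens) for inhibition, read by CCK-8 assay, with a stated time of 48 h; on this read-out lower numbers stand for stronger inhibition and higher numbers for weaker inhibition. Compound 1 `COc1cc(-c2cc3nccc(-c4c[nH]c5ccccc45)n3n2)cc(OC)c1OC` returns only a limit of the assay, > 10000 nM. Compound 3 `Cc1ccc(-c2cc3nccc(-c4ccc(F)cc4)n3n2)cc1` likewise returns only a limit, > 10000 nM. Within the data shown here, compound 2 `COc1cc(-c2ccnc3cc(-c4c[nH]c5ccccc45)nn23)cc(OC)c1OC` gives 35 nM and is therefore the sole compound with an actual number. The values of compound 1 and compound 3 are limits, as noted in the limit of > 10000 nM in this assay, at which 2 of the 3 values shown sit. Among the measured compounds shown here, no pair of measured compounds differs in a single place, so no measured step is available.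

Compound 4 `C=Cc1ccc(-c2cc3nccc(-c4cc(OC)c(OC)c(OC)c4)n3n2)cc1` has not yet been measured. Relative to compound 2 the change is 4-vinylphenyl in place of 1H-indol-3-yl on an aromatic carbon. The 1H-indol-3-yl group leaves with its hydrogen-bond donor and the 4-vinylphenyl group that enters brings none. For the measured compounds named here, with no measured step to lean on, the expectation for compound 4 is a loss of potency in this assay, an 11-fold higher number from compound 2 to compound 4 (1.06 log units; beyond the scatter), a step expected to exceed the usual scatter. For compound 4 the estimate in this assay is 400 nM, with a likely range from 60 nM to 5000 nM.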

Compound 4, half-maximal inhibitory concentration: 1060 nM
Compound 4: middle estimate off by 2.7-fold (0.42 log units), on the low side; low and high end bracket the measured number.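

On the aromatic carbon of the five-membered aromatic ring with 2 nitrogen, 4-vinylphenyl in place of 1H-indol-3-yl gives a 30-fold higher number from compound 2 to compound 4 (1.48 log units; beyond the scatter) in this assay, the first measured sign that this position is sensitive to the group it carries. The loss is partial: compound 4 still gives 1060 nM, so a measurable number in this assay does not depend on a hydrogen-bond donor in this group. Any reading rests on this single pair, the other values being limits: the limit of > 10000 nM in this assay, at which 2 of the 4 values shown sit.

The step does not separate the loss of the hydrogen-bond donor, the loss of the five-membered ring and the gain of the vinyl double bond. As far as these compounds go, how a plain phenyl or an aminophenyl would read at this carbon stays open, as does the effect of any change to the trimethoxyphenyl group.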